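Swapping the phenylsulfonyl group of compound 2

The source may report more compounds than this note shows. Statements on the series, on what has been measured and on what is new or still open speak of the compounds shown alone.

Compound 1 `Cc1ccc(S(=O)(=O)N[C@@H](CC(=O)NC(C)(C)C)C(=O)NCCNC(=O)c2cccc(O)c2)cc1`: > 11000 nM
Compound 2 `Cc1ccc(S(=O)(=O)N[C@@H](CC(=O)NC(C)(C)C)C(=O)NCCNS(=O)(=O)c2ccccc2)cc1`: > 11000 nM

In an ADME assay on HepG2 cells (Homo sapiens) for cytotoxicity (a lower number here means that less compound is needed, a higher number that more compound is needed for the effect), compound 2 gives > 11000 nM, which is a limit and not a number. Compound 1 gives > 11000 nM, which is also a limit. The measurements so far therefore amount to the limit of > 11000 nM in this assay, at which 2 of the 2 values shown sit.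

Compound 3 `C#Cc1cccc(C(=O)NCCNC(=O)[C@H](CC(=O)NC(C)(C)C)NS(=O)(=O)c2ccc(C)cc2)c1` keeps the core of compound 2 and differs in one group on an amine nitrogen: a group of 10 heavy atoms (9 carbon, 1 oxygen; one six-membered aromatic ring of carbon only) in place of a group of 9 heavy atoms (6 carbon, 2 oxygen, 1 sulfur; one six-membered aromatic ring of carbon only), on an amine nitrogen. Among the measured compounds shown here, the only measured change at this place is a step that the two limits leave unreadable from compound 1 to compound 2. That step offers no size to carry over, so no change beyond the usual scatter is expected in this assay, and compound 3 is expected to stay close to the same limit. The expected step is a step that the limit leaves unreadable from compound 2 to compound 3. The estimate for compound 3 is 15000 nM, with an expected range from 7000 nM to 30000 nM.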

Compound 3, half-maximal effective concentration: > 11000 nM
Compound 3: a limit, no number (the forecaster's own chance of this, stated with the estimate: 85%); the middle value does not contradict the limit.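

Compound 3 gives > 11000 nM in this assay, which is a limit and not a number. No new step can be read from compound 1 or compound 2 to compound 3. The compounds shown leave open what concentration of any of them reaches the half-maximal effect.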